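A few compounds are considered here, and "the series" means these few. Any claim that something is new, unique, unknown or untested is made for them only; others in the source may bear on it.

Measured so far in a physicochemical assay for lipophilicity; on this read-out higher numbers stand for higher lipophilicity and lower numbers for lower lipophilicity
- compound 1 `C=C1CC[C@@H]2[C@](C)(COC(C)=O)[C@H](OC(C)=O)CC[C@@]2(C)[C@@H]1C/C=C1\C=COC1=O` gives 3.87
- compound 2 `C=C1CC[C@@H]2[C@](C)(COC(C)=O)[C@H](OC(C)=O)CC[C@@]2(C)[C@@H]1/C=C/C1=CCOC1=O` gives 3.83

On these numbers, compound 2 stands level with compound 1. Within the data shown here, the only measured step is a number 0.04 log units lower from compound 1 to compound 2 (within the scatter). The next compound to be measured is compound 3 `C=C1CC[C@@H]2[C@](C)(COC(C)=O)[C@H](OC(C)=O)CC[C@@]2(C)[C@@H]1CCC1=CCOC1=O`. Its difference from compound 2 is a group of 8 heavy atoms (6 carbon, 2 oxygen; one five-membered non-aromatic ring with 1 hetero atom) in place of a group of 8 heavy atoms (6 carbon, 2 oxygen; one five-membered non-aromatic ring with 1 hetero atom), on a saturated ring carbon. On the saturated ring carbon, a group with 3 double bonds outside aromatic rings gives way to one with 2, and the five-membered non-aromatic ring with 1 hetero atom stays.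

Among the measured compounds shown here, the single measured step is the only guide, and it swaps two groups of equal size without changing the count of double bonds. For the measured compounds named here, no measured pair tests the loss of a double bond, so the evidence is thin. No shift beyond the scatter is expected, and the expected change is a number 0.07 log units higher from compound 2 to compound 3 (within the scatter). For compound 3 the estimated value is 3.9, with an expected range from 3.6 to 4.2.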

Compound 3, partition coefficient: 4.02
Beside the measured number, compound 3's estimate is 0.12 log units below it; the range from low to high includes it.
By their numbers in this assay, from the lowest: compounds 2, 1 and 3 (each within the scatter of the next).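

In this assay, the first measured drop from 3 double bonds outside aromatic rings to 2 in the group on the saturated ring carbon gives a number 0.19 log units higher from compound 2 to compound 3 (within the scatter), so removing this double bond leaves the value level with that of compound 2. The remaining pair gives a number 0.15 log units higher from compound 1 to compound 3 (within the scatter), which places all three groups at this position level with one another. No separate measurement bears on why these values lie so close.

From the compounds shown here alone, it stays open whether a longer chain carrying the five-membered ring, or an amine or a carboxylic acid in place of that ring, would shift this assay beyond the scatter. Going by these compounds, all three compounds keep the five-membered non-aromatic ring with 1 hetero atom, so the effect of removing it remains unknown.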